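The source may report more compounds than this note shows. Statements on the series, on what has been measured and on what is new or still open speak of the compounds shown alone.

In a functional assay on L1210 cells (Mus musculus) for inhibition (a higher number here means a weaker inhibitor, a lower number a stronger inhibitor), compound 1 `C=C1[C@@H](O)[C@H](n2cnc3c(N)nc(N)nc32)O[C@@H]1CO` gives > 200000 nM, which is a limit of the assay and not a number. Compound 2 `C=C1[C@@H](O)[C@H](n2cnc3c(N(C)C)nc(N)nc32)O[C@@H]1CO` gives > 500000 nM, which is also a limit. Within the data shown here, compound 3 `C=C1[C@H](n2cnc3c(N)nc(N)nc32)O[C@H](CO)[C@H]1O` gives 8200 nM, the only true number among the three values and the reference point for what follows.

Compound 4 `C=C1[C@H](n2cnc3c(S)nc(N)nc32)O[C@H](CO)[C@H]1O` differs from compound 3 by one exchange, sulfanyl in place of amino on an aromatic carbon. Among the measured compounds shown here, the one measured change that also replaces amino on an aromatic carbon is a step that the two limits leave unreadable from compound 1 to compound 2, and it offers no size to carry over. It also involves dimethylamino rather than sulfanyl. With no readable step to draw on, no direction can be argued from the data, so the expectation stays anchored on compound 3 at 8200 nM, with a wide margin on both sides. The expected change is a 1.6-fold lower number from compound 3 to compound 4 (0.21 log units; within the scatter). For compound 4 the estimated value is 5000 nM, with an expected range of 700 nM to 30000 nM.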

Compound 4, half-maximal inhibitory concentration: 20000 nM
Beside the measured number, compound 4's estimate is 4.0-fold (0.60 log units) below it, and the stated range covers the measured number.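

The exchange of amino for sulfanyl gives the first readable size at this position, next to the ring nitrogen: in this assay it is a 2.4-fold higher number from compound 3 to compound 4 (0.39 log units; beyond the scatter). The earlier step at this place, to dimethylamino, could not be read, so only now is it shown that this position registers a change, and that compound 4, carrying sulfanyl, still gives a true number and not a limit of the assay. Neither the donor and acceptor counts, which are the same for the two groups, nor anything else measured here gives a reason for the step.

From the compounds shown here alone, it remains open how a methoxy group or a single chlorine atom at this place would read on the core of compound 3. Also open, going by these compounds, is whether sulfanyl would give a step of similar size on the core of compound 1.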